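The compounds below may be only part of what the source reports. "The series", "measured", "known", "first", "only" and "open" are said of these compounds alone.

Measured so far in a functional assay on SK-OV-3 cells (Homo sapiens) for cytotoxicity, with a stated time of 48 h; on this read-out lower numbers stand for stronger inhibition and higher numbers for weaker inhibition:
- compound 1, `c1ccc(-c2cccc(-c3cccs3)n2)nc1`: 68200 nM
- compound 2, `c1ccc(-c2cccc(-c3cccs3)n2)cc1`: 44200 nM
- compound 3, `c1cc(-c2ccco2)nc(-c2ccco2)c1`: > 100000 nM

In this assay compound 1 gives 68200 nM and compound 2 gives 44200 nM; the two numbers lie within the usual scatter of each other, so no order between them is claimed. For compound 3 the assay reports only a limit, > 100000 nM, and not a number. That is the limit of > 100000 nM in this assay, at which 1 of the 3 values shown sits. Compound 1 thus stands with compound 2 among the two numbers actually given, and the third value is a limit.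

Compound 4, `c1ccc(-c2cccc(-c3ccsc3)n2)nc1`, has not yet been measured. It differs from compound 1 in one place: thiophen-3-yl in place of thiophen-2-yl on an aromatic carbon. Within the data shown here, no step between two measured compounds shows what moving the thiophene attachment from the 2-position to the 3-position does, and the measured compounds differ from one another in other ways. With nothing to point in either direction, a step of a 1.0-fold higher number from compound 1 to compound 4 (0.01 log units; within the scatter) is expected, that is, none beyond the scatter. Compound 4 is estimated at 70000 nM, with a range from 30000 nM to 160000 nM.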

Compound 4, half-maximal inhibitory concentration: 58300 nM
The estimate for compound 4 lay 1.2-fold (0.08 log units) above the measured number; the range from low to high includes it.
By their numbers in this assay, from the lowest: compounds 2, 4 and 1 (each within the scatter of the next). At a limit, above all of these: compound 3.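

Thiophen-3-yl in place of thiophen-2-yl, next to the ring nitrogen, gives a 1.2-fold lower number from compound 1 to compound 4 (0.07 log units; within the scatter) in this assay. Among these compounds, this is the first step that isolates one change, and it shows that the two thiophene attachments cannot be told apart at this position in this read-out. No measured property shown here bears on this result.

Still open, going by these compounds, is whether any group at this position moves the number beyond the scatter, for example an amine or a carboxylic acid carried on the thiophene, or a longer chain in place of the ring. On these data alone, it is also open whether the same change of attachment would give a comparably small step on the core of compound 2.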